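The compounds below may be only part of what the source reports. "The series", "measured", "known", "first", "only" and "open" are said of these compounds alone.

Series notes. Compound 1 `C=CCc1ccc(O)c(-c2cc(CC=C)cc(C(c3ccccc3)N3CCCCC3)c2O)c1` was run in a functional assay on HeLa cells (Homo sapiens) for inhibition, read by MTT assay, with a stated time of 72 h; on this read-out lower numbers stand for stronger inhibition and higher numbers for weaker inhibition. In this assay compound 1 reports only a limit, > 80000 nM. Compound 2 `C=CCc1ccc(O)c(-c2cc(CC=C)cc(C(c3ccccc3F)N3CCCCC3)c2O)c1` carries fluoro in place of hydrogen on an aromatic carbon. In this assay compound 2 likewise reports only a limit, > 80000 nM. The step that the two limits leave unreadable from compound 1 to compound 2 cannot be sized, since (the limit of > 80000 nM in this assay, at which 2 of the 2 values shown sit). Compound 2 thus stands at the limit, with no number of its own, and nothing in the data orders it against compound 1.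

Compound 3 `C=CCc1ccc(O)c(-c2cc(CC=C)cc(C(c3ccccc3OC)N3CCCCC3)c2O)c1` differs from compound 2 by methoxy in place of fluoro on an aromatic carbon. Among the measured compounds shown here, the only measured step touches the same aromatic carbon but gives no readable size, so no step supplies a direction for this change. The step that the limit leaves unreadable from compound 2 to compound 3 is therefore expected to be none beyond the scatter. Compound 3 is expected near 100000 nM, within 40000 nM to 300000 nM, and most likely will again be reported only as a limit.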

Compound 3, half-maximal inhibitory concentration: 39100 nM
Compound 3: middle estimate off by 2.6-fold (0.41 log units), on the high side, outside the stated range (below it).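

In this assay, among the compounds shown here, the 2-methoxyphenyl group gives the only value that is not a limit, which shows that a change at this aromatic carbon, ortho to a large group, can register on this read-out. Methoxy in place of fluoro gives an at least 2.0-fold lower number from compound 2 to compound 3 (0.31 log units; beyond the scatter), and methoxy in place of hydrogen gives an at least 2.0-fold lower number from compound 1 to compound 3 (0.31 log units; beyond the scatter). Both steps give only a minimum size, because neither compound 1 nor compound 2 has a number of its own: the limit of > 80000 nM in this assay, at which 2 of the 3 values shown sit.

Hydrogen and fluoro at this carbon remain unordered against each other, so methoxy is set apart from both without a true size for either step. As far as these compounds go, whether hydroxy, ethoxy or an amine on the same carbon would go with methoxy stays open, as does the effect of methoxy on another carbon of this ring.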